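The source may report more compounds than this note shows. Statements on the series, on what has been measured and on what is new or still open speak of the compounds shown alone.

Measured so far in a functional assay on Ehrlich cells (Mus musculus) for cytotoxicity, read by trypan blue exclusion, with a stated time of 2 h, tested at 10 ug/mL; a higher number here means a stronger effect of the compound at the concentration tested, a lower number a weaker effect:
compound 1, `N#CC1=C(N)N(c2ccc(S(N)(=O)=O)cc2)C2=C(CCCC2)C1c1ccccc1`, gives 5%;
compound 2, `Cc1ccc(C2C(C#N)=C(N)N(c3ccc(S(N)(=O)=O)cc3)C3=C2CCCC3)cc1`, gives 20%.

Compound 2 stands highest of these two numbers; its nearest neighbour, compound 1, lies lower by a step beyond the scatter. Compound 3, `N#CC1=C(N)N(c2ccc(S(N)(=O)=O)cc2)C2=C(CCCC2)C1c1ccccc1O`, differs from compound 2 in one place: 2-hydroxyphenyl in place of 4-methylphenyl on a saturated ring carbon. Within the data shown here, the only measured step, a number 15 percentage points higher from compound 1 to compound 2 (beyond the scatter), also concerned a group on an aromatic carbon, but a different group, so it bears on this change only loosely. A small downward step is expected, a number 10 percentage points lower from compound 2 to compound 3 (within the scatter), and in this assay compound 3 is estimated at 10%, between 0% and 30%.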

Compound 3, a percentage reported as activity, at one concentration (the size of the read-out at that concentration, not a potency): 10%
Compound 3: the middle estimate sits on the measured number at the digits printed; the range from low to high includes it.
By their numbers in this assay, from the lowest: compounds 1, 3 and 2 (each within the scatter of the next, the first and the last beyond it).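

Placing 2-hydroxyphenyl on the saturated ring carbon in place of 4-methylphenyl gives a number 10 percentage points lower from compound 2 to compound 3 (within the scatter) in this assay, and hydroxy in place of hydrogen on the aromatic carbon gives a number 5 percentage points higher from compound 1 to compound 3 (within the scatter). Compound 3 therefore cannot be told apart from either neighbour, although the methyl step was beyond the scatter. Nothing measured explains these numbers.

Going by these compounds, whether an amine or a carboxylic acid in place of the hydroxy would give a step beyond the scatter remains open.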